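The source may report more compounds than this note shows. Statements on the series, on what has been measured and on what is new or still open speak of the compounds shown alone.

Compound 1 `COC1=C(OC)[C@H](O)[C@H](C/C=C(\C)CC/C=C(\C)C[C@H](O)/C=C(\C)CO)[C@@H](C)C1=O` is the reference point of this small set. In a functional assay on A549 cells (Homo sapiens) for inhibition, read by sulforhodamine B assay, with a stated time of 48 h (on this read-out higher numbers stand for weaker inhibition of growth and lower numbers for stronger inhibition of growth), compound 1 gives 12000 nM, the lowest of the two numbers recorded. Compound 3 `COC1=C(OC)[C@H](OC(C)=O)[C@H](C/C=C(\C)CC/C=C(\C)C[C@H](O)/C=C(\C)CO)[C@@H](C)C1=O` gives 29000 nM in this assay. Compound 2 `COC1=C[C@H](O)[C@H](C/C=C(\C)CC/C=C(\C)C[C@H](O)/C=C(\C)CO)[C@@H](C)C1=O` reaches only the limit of the assay, > 30000 nM, in this assay. The step of a 2.4-fold higher number from compound 1 to compound 3 (0.38 log units; beyond the scatter) and the step of an at least 2.5-fold higher number from compound 1 to compound 2 (0.39 log units; beyond the scatter) both weaken growth inhibition. Compound 4 `COC1=C(OC)[C@H](O)[C@H](C/C=C(\C)CC/C=C(\C)CC/C=C(\C)CO)[C@@H](C)C1=O` differs from compound 1 by hydrogen in place of hydroxy on a saturated chain carbon bound to a double-bonded chain carbon and a saturated chain carbon. Among the measured compounds shown here, no measured step touches this chain hydroxy, but both measured changes that removed or masked an oxygen function weakened the compound, so a modest weakening is expected, a step of a 1.8-fold higher number from compound 1 to compound 4 (0.26 log units; within the scatter). Compound 4 is therefore estimated to give 22000 nM, within 8000 nM to 45000 nM.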

Compound 4, concentration for 50% growth inhibition: 8200 nM
Estimate against measurement, compound 4: 2.7-fold (0.43 log units) above, within the range that was stated.
By their numbers in this assay, from the lowest: compounds 4 and 1 (each within the scatter of the next); then compound 3. At a limit, above all of these: compound 2.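

At this saturated chain carbon, hydrogen in place of hydroxy gives a 1.5-fold lower number from compound 1 to compound 4 (0.17 log units; within the scatter) in this assay, so compound 1 and compound 4 cannot be told apart here. Not every loss of an oxygen function therefore weakens growth inhibition: the steps at the methoxy and at the acetylated oxygen lie beyond the scatter, whereas this one does not. Nothing shown bears on why this position differs from those two. From the compounds shown here alone, how an amine or an acetoxy group at this same chain carbon would read remains open.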